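A few compounds are considered here, and "the series" means these few. Any claim that something is new, unique, unknown or untested is made for them only; others in the source may bear on it.

Measured in a functional assay on MCF7 cells (Homo sapiens) for inhibition, read by sulforhodamine B assay, with a stated time of 48 h; on this read-out lower numbers stand for stronger inhibition of growth and higher numbers for weaker inhibition of growth:
compound 1 `c1cc(OC2CCCC2)ccc1NC1=NCCO1`: 23100 nM
compound 2 `c1ccc(Oc2ccc(NC3=NCCO3)cc2)cc1`: 3500 nM
compound 3 `O=C(CCl)NC(=O)Nc1cccc(OC2CCCCC2)c1`: 6300 nM

Compound 2 and compound 3 lie within the scatter of each other, and compound 1 stands apart from compound 2. For the measured compounds named here, the only measured step, a 6.6-fold lower number from compound 1 to compound 2 (0.82 log units; beyond the scatter), concerns the group on the oxygen, so it bears on the next change only indirectly.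

Compound 4 `O=C(CCl)NC(=O)Nc1ccc(Oc2ccccc2)cc1` keeps the phenyl of compound 2 on the oxygen and differs by a group of 7 heavy atoms (3 carbon, 1 nitrogen, 2 oxygen, 1 chlorine; no ring) in place of a group of 5 heavy atoms (3 carbon, 1 nitrogen, 1 oxygen; one five-membered non-aromatic ring with 2 hetero atoms), on a nitrogen on an aromatic ring. Compound 3, which already carries ((chloromethyl)carbonyl)carbamoyl, gives 6300 nM, so no step beyond the scatter is expected in this assay. The expected step is a 1.2-fold lower number from compound 2 to compound 4 (0.07 log units; within the scatter). For compound 4 the estimated value is 3000 nM, with an expected range of 1000 nM to 9000 nM.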

Compound 4, concentration for 50% growth inhibition: 4200 nM
Compound 4: the middle estimate sits 1.4-fold (0.15 log units) below what was measured; the range from low to high includes it.
By their numbers in this assay, from the lowest: compounds 2, 4 and 3 (each within the scatter of the next); then compound 1.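

In this assay the exchange on a nitrogen on an aromatic ring, ((chloromethyl)carbonyl)carbamoyl for the group with the five-membered ring, gives a 1.2-fold higher number from compound 2 to compound 4 (0.08 log units; within the scatter) and so shows that, with phenyl on the oxygen, this position accepts an open-chain group in place of the ring without a step beyond the scatter. The read-out does not separate the two groups, although they differ in hydrogen-bond donors. Nothing available explains this result.

Going by these compounds, whether the chlorine matters remains open, as an unsubstituted acetyl group on the same carbamoyl would test. Also open, on these data alone, is how a simple amine or a longer alkyl chain would behave on this nitrogen.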